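This account rests on a few compounds, and the source may have more. Where it says the series, first, only, none or still open, it means among the compounds named here.

Working notes on the series.

Compound 1 `Cc1cc(S(N)(=O)=O)ccc1NC(=O)COc1ccc(Cl)cc1NC(=O)c1cccc([N+](=O)[O-])c1` is one of three analogues measured in a functional assay on C8166 cells (Homo sapiens) for cytotoxicity, read by MTT assay; a lower number here means that less compound is tolerated, a higher number that more compound is tolerated. In this assay compound 1 gives 58800 nM, the lowest of the three numbers; compound 2 `Cc1ccc(C)c(C(=O)Nc2cc(Cl)ccc2OCC(=O)Nc2ccc(S(N)(=O)=O)cc2C)c1` gives 79700 nM, and compound 3 `Cc1cc(S(N)(=O)=O)ccc1NC(=O)COc1ccc(Cl)cc1NC(=O)/C=C/c1ccccc1` gives 163000 nM. The step of a 1.4-fold higher number from compound 1 to compound 2 (0.13 log units; within the scatter) lies within the scatter, whereas a 2.8-fold higher number from compound 1 to compound 3 (0.44 log units; beyond the scatter) and a 2.0-fold higher number from compound 2 to compound 3 (0.31 log units; beyond the scatter) are modest steps beyond it.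

Compound 4 `Cc1cc(S(N)(=O)=O)ccc1NC(=O)COc1ccc(Cl)cc1NC(=O)c1ccc2ccccc2c1` has not yet been measured. It differs from compound 1 as follows: naphthalen-2-yl in place of 3-nitrophenyl on a carbonyl carbon. The two measured steps that start from compound 1 both exchange the group on the carbonyl carbon, and both left the number the same or moved it modestly higher, so the exchange of 3-nitrophenyl for naphthalen-2-yl is expected to behave in the same way: either no change beyond the scatter or a small rise in this assay. Compound 4 is therefore estimated at 80000 nM, with a range from 40000 nM to 160000 nM, which corresponds to an expected step of a 1.4-fold higher number from compound 1 to compound 4 (0.13 log units; within the scatter).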

Compound 4, half-maximal cytotoxic concentration: 37600 nM
The estimate for compound 4 lay 2.1-fold (0.33 log units) above the measured number, and the stated range ends above it.
By their numbers in this assay, from the lowest: compounds 4, 1 and 2 (each within the scatter of the next, the first and the last beyond it); then compound 3.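

Replacing 3-nitrophenyl with naphthalen-2-yl on the carbonyl carbon gives a 1.6-fold lower number from compound 1 to compound 4 (0.19 log units; within the scatter), so exchanging a group with 2 hydrogen-bond acceptors for one with none, and one aromatic ring for 2, leaves the number level in this assay. Among these compounds, the earlier steps from compound 1 showed no fall, but this position can also lower the number: the step from 2,5-dimethylphenyl gives a 2.1-fold lower number from compound 2 to compound 4 (0.33 log units; beyond the scatter) and the step from 2-phenylethenyl gives a 4.3-fold lower number from compound 3 to compound 4 (0.64 log units; beyond the scatter), the largest step so far. No measurement shown here accounts for these differences.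

On these data alone, it remains open whether an amine, a carboxylic acid or a saturated ring such as cyclohexyl on this carbonyl carbon would fall within the same span in this assay. As far as these compounds go, whether these groups keep the same order on a different core also remains open.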